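The compounds below may be only part of what the source reports. "The series", "measured", "known", "first", "only" and "open" are said of these compounds alone.

Measured so far in a functional assay for inhibition, with Rattus norvegicus as the target; on this read-out lower numbers stand for stronger inhibition and higher numbers for weaker inhibition:
- compound 1, `CCCCc1cc(OC)c2occc2c1OC(C)=O`: 110 nM
- compound 2, `CCCCc1cc(OC)c2occc2c1O`: 11900 nM
- compound 3, `CCCCc1cc(OC)c2sccc2c1OC(C)=O`: 460 nM

Compound 1 and compound 2 share a core and differ in one place, (hydrogen in place of acetyl on an oxygen on an aromatic ring). This change produced a 110-fold higher number from compound 1 to compound 2 (2.03 log units; beyond the scatter), a large loss of potency that lies well beyond the usual scatter. Compound 3 carries a different core from compound 1; how the two cores differ is not broken down here, and the two values are simply what they are, with compound 3 the weaker of the pair in this assay.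

Compound 4, `CCCCc1cc(OC)c2sccc2c1O`, has not yet been measured. It differs from compound 3 by hydrogen in place of acetyl on an oxygen on an aromatic ring, the same change, at the same place, as that between compound 1 and compound 2; among these four compounds the change occurs twice. Going by the values given here, with only one measured instance, the expectation for compound 4 rests on that single pair: a step of about the same size is expected, an 87-fold higher number from compound 3 to compound 4 (1.94 log units; beyond the scatter), because the matched pair gave a 110-fold higher number from compound 1 to compound 2 (2.03 log units; beyond the scatter). Compound 4 is therefore estimated at 40000 nM in this assay, with an expected range from 10000 nM to 150000 nM.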

Compound 4, half-maximal inhibitory concentration: 1050 nM
Estimate against measurement, compound 4: 38-fold (1.58 log units) above, and the stated range ends above it.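

In this assay, acetoxy to hydroxy on the core of compound 3 gives a 2.3-fold higher number from compound 3 to compound 4 (0.36 log units; beyond the scatter), a modest step. The direction of the change is the same in both matched pairs, but its size does not carry from one core to the other: the same change on two cores in this assay, a 110-fold higher number (2.03 log units; beyond the scatter) from compound 1 to compound 2 and a 2.3-fold higher number (0.36 log units; beyond the scatter) from compound 3 to compound 4, 47-fold (1.68 log units) apart, beyond the scatter of two such steps These two pairs show that the size of the step depends on the core in this series, but they do not show which difference between the cores sets that size, or how the change would behave on a third core.

The compounds shown leave open whether the same gap between the cores would appear with another group in place of acetyl on that oxygen, such as benzoyl or methyl. They also leave open whether it would persist if the butyl chain, which is common to all four compounds, gave way to a longer chain or to one ending in an amine.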